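The source may hold more compounds than are shown below. What is called first, only, known or untested is meant among the compounds shown, and "the series" means these compounds.

Measured so far in an ADME assay on BHK cells (Mesocricetus auratus) for cytotoxicity, read by MTT assay, with a stated time of 96 h; on this read-out higher numbers stand for lower toxicity in this test and lower numbers for higher toxicity in this test:

- compound 1, `Fc1ccccc1NC(=S)Nc1cccc(C(F)(F)F)c1`, gives 54000 nM
- compound 2, `COc1cccc(NC(=S)Nc2cccc(C(F)(F)F)c2)c1`, gives 12000 nM
- compound 3, `Fc1ccc(NC(=S)Nc2cccc(C(F)(F)F)c2)cc1`, gives 26000 nM

Compound 3 holds the second highest of the three numbers in this assay: compound 1 sits above it and compound 2 below it, both gaps beyond the usual scatter. The step under review leads from compound 3 to compound 4, `FC(F)(F)c1cccc(NC(=S)Nc2ccccc2)c1`. The change is: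

hydrogen in place of fluoro on an aromatic carbon

Among the measured compounds shown here, the only measured step that touches the same part of the molecule is a 2.1-fold lower number from compound 1 to compound 3 (0.32 log units; beyond the scatter), a modest shift that moves the fluoro from one position to another rather than removing it. For the measured compounds named here, compound 2 carries a methoxy at this side of the shared core and gives the lowest number, but no measured pair shows a substituent replaced by hydrogen, so the direction of the present step is not anchored by a directly comparable step. The closest measured change was modest; the expectation for the step from compound 3 to compound 4 in this assay is therefore a change no larger than that, most likely within the scatter, a 1.1-fold higher number from compound 3 to compound 4 (0.03 log units; within the scatter). On that basis compound 4 is estimated at 28000 nM in this assay, with a range from 12000 nM to 65000 nM.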

Compound 4, half-maximal cytotoxic concentration: 41000 nM
Compound 4: middle estimate off by 1.5-fold (0.17 log units), on the low side, within the range that was stated.
By their numbers in this assay, from the lowest: compound 2; then compounds 3, 4 and 1 (each within the scatter of the next, the first and the last beyond it).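

In this assay the fluoro can now be read against hydrogen itself: the record shows a 1.6-fold higher number from compound 3 to compound 4 (0.20 log units; within the scatter) and a 1.3-fold lower number from compound 1 to compound 4 (0.12 log units; within the scatter) for the same replacement. Removing the fluoro therefore gives no separable change from either of the two fluoro compounds, so 4-fluorophenyl to phenyl is a tolerated swap on this read-out. Methoxy behaves differently, with a 3.4-fold higher number from compound 2 to compound 4 (0.53 log units; beyond the scatter) as the only replacement by hydrogen shown here that clears the scatter.

No measurement at hand accounts for these differences.

From the compounds shown here alone, whether an amine or a carboxylic acid on this aromatic carbon would group with the hydrogen and fluoro compounds or with the methoxy compound remains open. Also open, going by these compounds, is whether the methoxy step depends on where that group sits on the ring.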